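From fluoro to methyl on compound 1

The compounds below may be only part of what the source reports. "The series", "measured", "known", "first", "only" and "open" are said of these compounds alone.

Measured in a functional assay on the whole organism for antagonist activity, with Mus musculus as the target, in the maximal electroshock model; on this read-out lower numbers stand for an effect already at smaller amounts and higher numbers for an effect only at larger amounts of compound:
compound 1 (`CSc1nnc(-c2ccc(F)cc2)n1C`): > 200 mg/kg
compound 2 (`Cn1c(-c2ccccc2)nnc1[S+](C)[O-]`): > 100 mg/kg

In this assay compound 1 gives > 200 mg/kg as its reading, which is a limit and not a number. Compound 2 gives > 100 mg/kg as its reading, and this too is a limit. Among the compounds with values here, neither compound therefore has a numerical value here, and no measured step between compounds is available as a guide.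

Compound 3 (`CSc1nnc(-c2ccc(C)cc2)n1C`) carries methyl in place of fluoro on an aromatic carbon of a six-membered aromatic ring of carbon only, para to a group of 8 heavy atoms (methyl in place of fluoro on an aromatic carbon) on the core of compound 1.

The expectation rests on compound 1 with > 200 mg/kg as its limit and on nothing firmer. The expected step, a step that the limit leaves unreadable from compound 1 to compound 3 in this assay, is estimated to stay within the scatter, with no direction favoured. For compound 3 the estimated value is 250 mg/kg within a range from 100 mg/kg to 500 mg/kg and a reading that is again only a limit is expected to be likely.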

Compound 3, dose for half-maximal effect: > 100 mg/kg
Compound 3: a limit, no number; the forecaster's own chance of this, stated with the estimate: 70%; the middle value lies beyond the limit too.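

In this assay compound 1 and compound 3 both read as limits and not numbers, and the step for methyl in place of fluoro on an aromatic carbon cannot be read. The compounds shown leave open whether any compound of this series gives a numerical value in this assay.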